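The compounds below may be only part of what the source reports. "The series", "measured", "known", "first", "only" and "open" are said of these compounds alone.

Measured in a functional assay on MIA PaCa-2 cells (Homo sapiens) for antiproliferative activity, read by MTT assay, with a stated time of 72 h; a higher number here means a weaker inhibitor, a lower number a stronger inhibitor:
- compound 1 `O=C1O/C(=C\Cn2cnc3cc[nH]c3c2=O)C(OCc2ccccc2)=C1OCc1ccccc1`: > 100000 nM (a limit of the assay)
- compound 2 `O=C1O/C(=C\Cn2cnc3cncc(Br)c32)C(OCc2ccccc2)=C1OCc1ccccc1`: 22600 nM
- compound 3 `O=C1O/C(=C\Cn2cnc3ccnc(Cl)c32)C(OCc2ccccc2)=C1OCc1ccccc1`: > 100000 nM (a limit of the assay)

Compound 3 stands at > 100000 nM, which is a limit and not a number. Going by the values given here, the series so far sits largely at the limit of > 100000 nM in this assay, at which 2 of the 3 values shown sit.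

The next compound is compound 4 `O=C1O/C(=C\Cn2cnc3ncc(Br)c-3c2)C(OCc2ccccc2)=C1OCc1ccccc1`. The change is a group of 10 heavy atoms (6 carbon, 3 nitrogen, 1 bromine; one five-membered aromatic ring with 1 hetero atom, one six-membered aromatic ring with 2 hetero atoms) in place of a group of 10 heavy atoms (6 carbon, 3 nitrogen, 1 chlorine; one five-membered aromatic ring with 2 hetero atoms, one six-membered aromatic ring with 1 hetero atom), on a saturated chain carbon bound to a double-bonded chain carbon.

Among the compounds with values here, two measured steps bear on this change: an at least 4.4-fold lower number from compound 1 to compound 2 (0.64 log units; beyond the scatter) and an at least 4.4-fold higher number from compound 2 to compound 3 (0.64 log units; beyond the scatter). Both are beyond the scatter, and each gives only a minimum size. Within the data shown here, compound 2 is the sole compound with a number so far, at 22600 nM, and it carries bromine, as compound 4 will. Compound 1 has the same ring counts as the entering group. Compound 1 rests at > 100000 nM, which is a limit.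

A drop of about the size seen between the bromine and chlorine compounds is therefore expected in this assay, though a second limit remains quite possible. The expected change is an at least 2.8-fold lower number from compound 3 to compound 4 (0.45 log units; beyond the scatter). For compound 4 the estimated value is 35000 nM, with an expected range of 10000 nM to 100000 nM.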

Compound 4, half-maximal inhibitory concentration: > 100000 nM
Compound 4: a limit, no number; the forecaster's own chance of this, stated with the estimate: 40%; middle value at least 2.8-fold (0.45 log units) away from the limit.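

In this assay compound 4 gives > 100000 nM, which is a limit of the assay and not a number. Both groups in this comparison carry bromine, so bromine alone does not hold the activity at this place, on a saturated chain carbon bound to a double-bonded chain carbon: the change of ring arrangement within the group gives an at least 4.4-fold higher number from compound 2 to compound 4 (0.64 log units; beyond the scatter). The steps to compound 4 from compound 1 and from compound 3 cannot be read, with limits at both ends, and compound 2 remains the only compound with a number, so the series now rests largely on one reading: the limit of > 100000 nM in this assay, at which 3 of the 4 values shown sit.

The compounds shown do not separate the part played by bromine from that of the ring arrangement in compound 2, since no compound carries chlorine, methyl or an amine in place of bromine on that same group. Also open, as far as these compounds go, is how compound 2 responds to changes elsewhere on the shared core, such as a free hydroxyl or a methyl ether in place of the benzyl ethers.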